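A few compounds are considered here, and "the series" means these few. Any claim that something is new, unique, unknown or untested is made for them only; others in the source may bear on it.

Two compounds carry a shared core with a sugar-like side chain and have been tested in a functional assay on THP-1 cells (Homo sapiens) for inhibition, read by ELISA, tested at 10 uM; on this read-out higher numbers stand for more inhibition at the one concentration tested (going by the name of the read-out) and lower numbers for less inhibition. Compound 1, `COC[C@H](O)[C@@H](OC)[C@@H](OC)C1=CC2C(C)=NN(C)C2N=C1`, has a methyl group on one ring nitrogen of the core, and in this assay compound 1 gives 35%. Compound 2, `CCO[C@@H](C1=CC2C(C)=NN(c3ccccc3)C2N=C1)[C@H](OC)[C@@H](O)COC`, carries a phenyl group on that ring nitrogen instead, and in this assay compound 2 gives 44%. The gap between the two values lies within the usual scatter of repeated measurements, so neither compound can be set apart from the other on these numbers.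

Compound 3, `CCO[C@@H](C1=CC2C(c3ccc(OC)cc3)=NN(c3ccccc3)C2N=C1)[C@H](OC)[C@@H](O)COC`, is not yet measured. It differs from compound 2 in one place: 4-methoxyphenyl in place of methyl on a carbon with a double bond to nitrogen. Within the data shown here, no measured pair shows the effect of such a change here, so there is nothing to say about its size beyond the structure itself.

The step from compound 2 to compound 3 is therefore expected to be a number 1 percentage points higher from compound 2 to compound 3 (within the scatter), with no clear direction beyond the scatter. On that basis compound 3 is estimated to give 45% in this assay, within a range from 20% to 70%.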

Compound 3, a percentage reported as inhibition, at one concentration (the size of the read-out at that concentration, not a potency): 35%
For compound 3 the middle estimate is 10 percentage points above the measured one, and the stated range covers the measured number.
By their numbers in this assay, from the lowest: compounds 1, 3 and 2 (each within the scatter of the next).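

On the carbon with a double bond to nitrogen, replacing methyl with 4-methoxyphenyl gives a number 9 percentage points lower from compound 2 to compound 3 (within the scatter) in this assay, even though the group grows from 1 heavy atom to 8 and brings a six-membered aromatic ring and 1 hydrogen-bond acceptor. Compound 1 and compound 2 both carry methyl on this carbon, so they could not show that this much larger group can sit here without a change that stands clear of the scatter. No measurement at hand offers an explanation for this result.

On these data alone, it remains open whether any group on this carbon can move the read-out beyond the scatter, as a plain phenyl, an amine or a carboxylic acid in the same place would help to show. As far as these compounds go, it is also open whether 4-methoxyphenyl would give a similar result with methyl rather than phenyl on the ring nitrogen, a comparison that would show whether the two positions act independently.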